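This account rests on a few compounds, and the source may have more. Where it says the series, first, only, none or still open, it means among the compounds named here.

For the measured compounds named here, in a functional assay on A375P cells (Homo sapiens) for cytotoxicity, read by MTT assay (on this read-out higher numbers stand for weaker inhibition and lower numbers for stronger inhibition), compound 2 `O=C(Nc1ccc(-n2ccc3nc(C(=O)NCc4ccccc4)ccc32)cc1)c1ccc(Cl)c(C(F)(F)F)c1` gives 700 nM, the lower of the two numbers measured so far. The other measured compound, compound 1 `COC(=O)c1ccc2c(ccn2-c2cccc(NC(=O)Nc3ccc(Cl)c(C(F)(F)F)c3)c2)n1`, gives 9500 nM in this assay, a weaker result that lies beyond the usual scatter of repeated measurements. Compound 3 `O=C(Nc1ccc(-n2ccc3nc(C(=O)NCc4ccccc4)ccc32)cc1)Nc1cccc(Cl)c1Cl` has not yet been measured. It differs from compound 2 in one place: (2,3-dichlorophenyl)amino in place of 4-chloro-3-(trifluoromethyl)phenyl on a carbonyl carbon. The change sits on a carbonyl carbon whose other neighbour is an amide-type nitrogen, so the group that enters brings one hydrogen-bond donor where the group that leaves had none. Going by the values given here, no measured pair in this set shows what such a change does on this core, and compound 1 carries both a different ring substitution and a different core, so it gives no direct guide. The step from compound 2 to compound 3 is therefore expected to be modest, a 1.4-fold higher number from compound 2 to compound 3 (0.15 log units; within the scatter), with a somewhat weaker result more likely than a stronger one. For compound 3 the estimate in this assay is 1000 nM, within a range from 300 nM to 5000 nM.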

Compound 3, half-maximal inhibitory concentration: > 10000 nM
Compound 3 gave a limit, no number (the forecaster's own chance of this, stated with the estimate: 5%); middle value at least 10-fold (1.00 log units) away from the limit.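

For the compounds shown here, this is the first pair in the set that differs in one place, so it gives the first direct reading of this position. On the shared core, (2,3-dichlorophenyl)amino in place of 4-chloro-3-(trifluoromethyl)phenyl on a carbonyl carbon gives an at least 14-fold higher number from compound 2 to compound 3 (1.15 log units; beyond the scatter) in this assay, which shows that activity in this assay is sensitive to what sits here. Compound 3 gives a limit of the assay and not a number: the limit of > 10000 nM in this assay, at which 1 of the 3 values shown sits.

This single step swaps the ring substituents and adds an amino nitrogen with its hydrogen-bond donor, so the compounds shown cannot say which of these changes matters. From the compounds shown here alone, how a plain phenyl, a methoxyphenyl or the same 4-chloro-3-(trifluoromethyl)phenyl joined through an amino nitrogen would behave on this core also stays open.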